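This account rests on a few compounds, and the source may have more. Where it says the series, first, only, none or still open, it means among the compounds named here.

Measured compounds:
- compound 1 `CC(C)(C)NCC(=O)N1N=C(c2cc3ccccc3oc2=O)CC1c1ccccc1`: 31400 nM
- compound 2 `CC1CCCN(CC(=O)N2N=C(c3cc4ccccc4oc3=O)CC2c2ccccc2)C1`: "not active" (no number reported)

Compound 1 carries a tert-butylaminoacetyl group on the shared core. In a functional assay on HepG2 cells (Homo sapiens) for cytotoxicity, read by MTT assay, with a stated time of 48 h (a higher number here means a weaker inhibitor, a lower number a stronger inhibitor), compound 1 gives 31400 nM, a weak result. Compound 2 `CC1CCCN(CC(=O)N2N=C(c3cc4ccccc4oc3=O)CC2c2ccccc2)C1` differs in the basic group on the chain and in this assay compound 2 is reported as "not active" (no number reported), so no single number places it among the others; it stands only as a compound without a measured value. Compound 3 `NC(=O)C1CCN(CC(=O)N2N=C(c3cc4ccccc4oc3=O)CC2c2ccccc2)CC1` is the next member, not yet measured. Relative to compound 2 the change is 4-carbamoylpiperidin-1-yl in place of 3-methylpiperidin-1-yl on a saturated chain carbon bound to a carbonyl carbon. Nothing measured here ties this change to a known step in this assay, so no direction can be read from the data. Given the weak result of compound 1 and the absence of a number for compound 2, compound 3 is expected to fall around 50000 nM, with a range of 15000 nM to 200000 nM, and the assay may again report only a limit.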

Compound 3, half-maximal inhibitory concentration: 19300 nM
Estimate against measurement, compound 3: 2.6-fold (0.41 log units) above, within the range that was stated.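

In this assay, the 4-carbamoylpiperidin-1-yl group in place of (tert-butyl)amino on a saturated chain carbon bound to a carbonyl carbon gives a 1.6-fold lower number from compound 1 to compound 3 (0.21 log units; within the scatter), so the two groups cannot be told apart in this read-out, despite their different size and shape. Within the data shown here, compound 2 is reported as "not active" (no number reported), so no step involving it can be read, and the swap from 3-methylpiperidin-1-yl to 4-carbamoylpiperidin-1-yl remains without a size or direction. No measurement available here explains these results.

Going by these compounds, it remains open whether a carboxylic acid in place of the carbamoyl group on the piperidine would change the number in this assay. Equally open, on these data alone, is where a morpholin-4-yl group or an unsubstituted piperidin-1-yl group at this place would fall.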